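The compounds below may be only part of what the source reports. "The series", "measured", "known", "first", "only" and "open" are said of these compounds alone.

Compound 3, `CCOC(=O)[C@@H]1CCCN(S(=O)(=O)c2ccc(C(=O)N(CC)CC)cc2)C1`, gives the lowest number of the three measured compounds in a functional assay on BXPC-3 cells (Homo sapiens) for inhibition, read by MTT assay, with a stated time of 7 days (a lower number here means a stronger inhibitor, a higher number a weaker inhibitor), with 640 nM. Compound 1, `CCN(CC)S(=O)(=O)c1ccc(S(=O)(=O)N2CCC[C@@H](C(=O)NC3CN(C(=O)OC(C)(C)C)C3)C2)cc1`, gives 1800 nM in this assay, and compound 2, `CCN(CC)S(=O)(=O)c1ccc(S(=O)(=O)N2CCC[C@@H](C(=O)NC3CN(S(C)(=O)=O)C3)C2)cc1`, gives 7400 nM. Among the measured compounds shown here, the one step that can be followed between measured compounds, a 4.1-fold higher number from compound 1 to compound 2 (0.61 log units; beyond the scatter), concerns a change at a ring nitrogen far from the aromatic ring and so says nothing directly about the change now considered.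

Compound 4, `CCOC(=O)[C@@H]1CCCN(S(=O)(=O)c2ccc(S(=O)(=O)N(C)C)cc2)C1`, differs from compound 3 in one place: dimethylsulfamoyl in place of diethylcarbamoyl on an aromatic carbon. For the measured compounds named here, no measured pair isolates this exchange; compounds 1 and 2 carry a sulfamoyl group on the aromatic ring but differ from compound 3 at the other end of the core as well, so their values cannot be read as a step for this change alone. Going by the values given here, with no step to lean on, the expected change is a small one, within the scatter or close to it, in either direction, that is, a 1.3-fold higher number from compound 3 to compound 4 (0.10 log units; within the scatter). For compound 4 the expected value in this assay is therefore 800 nM, within a range of 300 nM to 2500 nM.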

Compound 4, half-maximal inhibitory concentration: 1000 nM
The estimate for compound 4 lay 1.3-fold (0.10 log units) below the measured number, within the range that was stated.
By their numbers in this assay, from the lowest: compounds 3, 4 and 1 (each within the scatter of the next, the first and the last beyond it); then compound 2.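

In this assay the exchange of diethylcarbamoyl for dimethylsulfamoyl on an aromatic carbon, para to a large group, gives a 1.6-fold higher number from compound 3 to compound 4 (0.19 log units; within the scatter) and so stays within the scatter. Among the compounds shown here, at this position, then, the two groups cannot be told apart in this assay, although they differ in their atoms and in their count of hydrogen-bond acceptors; the earlier compounds could not show this, since their one step lay at an amine nitrogen in a ring. Nothing available here bears on why the two groups read alike.

The exchange alters the linking group and the alkyl chains together, so the compounds shown leave open what each contributes alone, which dimethylcarbamoyl could separate. They also leave open whether a simple amine or a carboxylic acid on this aromatic carbon would read the same way.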